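The source may hold more compounds than are shown below. What is called first, only, known or untested is meant among the compounds shown, and "the series" means these compounds.

Measured so far:
- compound 1, `CCOc1ccc(O)c(C(=O)/C=C/c2ccc(C)s2)c1`: 23200 nM in a functional assay on MCF7 cells (Homo sapiens) for cytotoxicity, read by MTT assay; a lower number here means a stronger inhibitor, a higher number a weaker inhibitor
- compound 2, `Cc1ccc(/C=C/C(=O)c2cc(OC(C)C)ccc2O)s1`: 15500 nM
- compound 3, `CCCOc1ccc(OC)cc1C(=O)/C=C/c1ccc(C)s1`: 800 nM

Compound 1 and compound 2 differ by methyl in place of hydrogen on a saturated chain carbon bound to an oxygen on an aromatic ring and a saturated chain carbon; the step is a 1.5-fold lower number from compound 1 to compound 2 (0.18 log units; within the scatter), so their two values cannot be ordered. Compound 3 stands apart from both: its number is lower than that of compound 2 and of compound 1 by gaps beyond the scatter. How the core of compound 3 differs from the core of compound 1 is not broken down here.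

Compound 4, `CCCCOc1ccc(OC)cc1C(=O)/C=C/c1ccc(C)s1`, is not yet measured. It differs from compound 3 by methyl in place of hydrogen on a saturated chain carbon, three bonds along the chain from an oxygen on an aromatic ring. Going by the values given here, this is the same kind of change as the one between compound 1 and compound 2, not the same: there the added methyl sat on a saturated chain carbon bound to an oxygen on an aromatic ring and a saturated chain carbon, here it sits on a saturated chain carbon, three bonds along the chain from an oxygen on an aromatic ring, and the cores also differ. Among the compounds with values here, because the only precedent is a 1.5-fold lower number from compound 1 to compound 2 (0.18 log units; within the scatter), the step expected from compound 3 to compound 4 is small, a 1.1-fold lower number from compound 3 to compound 4 (0.06 log units; within the scatter). Compound 4 is therefore expected to give about 700 nM in this assay, likely between 300 nM and 2000 nM.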

Compound 4, half-maximal inhibitory concentration: 13900 nM
Beside the measured number, compound 4's estimate is 20-fold (1.30 log units) below it; measured number outside the range, above it.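

In this assay, the added methyl that turns propyl into butyl gives a 17-fold higher number from compound 3 to compound 4 (1.24 log units; beyond the scatter). The same kind of change therefore did not carry over with the same size from one core to the other in this series, since the two steps are clearly different: the same change on two cores in this assay, a 1.5-fold lower number (0.18 log units; within the scatter) from compound 1 to compound 2 and a 17-fold higher number (1.24 log units; beyond the scatter) from compound 3 to compound 4, 26-fold (1.42 log units) apart, beyond the scatter of two such steps. This does not show whether the core or the place of the methyl accounts for that gap, as the two steps differ in both, and with a single step on each core it gives no rule for any other core.

The compounds shown leave open what a longer chain such as pentyl, or a chain ending in an amine, would give on the core of compound 3. They also leave open whether turning propyl into butyl on the core of compound 1 would give a step like the one seen on the core of compound 3.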